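The source may hold more compounds than are shown below. What is called first, only, known or untested is meant among the compounds shown, and "the series" means these compounds.

Series notes, maximal response in an in vitro functional assay on HEK285-7 cells for antagonist activity at prostaglandin D2 receptor 2 (Homo sapiens), read by BRET and beta-arrestin recruitment; on this read-out lower numbers stand for smaller maximal responses and higher numbers for larger maximal responses. Three compounds have numbers. Compound 1 `O=C(O)Cc1sc(Cc2ccccc2-c2ccccc2)nc1-c1ccc(Cl)cc1` gives 50% in this assay. Compound 2 `NS(=O)(=O)c1ccc(-c2nc(C(c3ccc(F)cc3)c3ccc(F)cc3)sc2CC(=O)O)cc1` gives 80% in this assay. Compound 3 `O=C(O)Cc1sc(CS(=O)(=O)c2ccc(Cl)cc2)nc1-c1ccc(Cl)cc1` gives 30% in this assay. Compound 2 stands highest of the three, beyond the scatter from compound 1 and further still from compound 3, so it shows the largest maximal response seen so far.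

Compound 4 `O=C(O)Cc1sc(C(c2ccc(F)cc2)c2ccc(F)cc2)nc1-c1ccco1` is not yet measured. It differs from compound 2 in one place:
furan-2-yl in place of 4-sulfamoylphenyl on an aromatic carbon

Going by the values given here, no measured pair isolates this change. Among the compounds with values here, the only other numbers, compound 1 at 50% and compound 3 at 30%, come from cores without the sulfamoyl group, and both sit well below compound 2. A step downward beyond the scatter is therefore expected. For compound 4 the estimate is 55% in this assay, within 30% to 80%, which means an expected step of a number 25 percentage points lower from compound 2 to compound 4 (beyond the scatter).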

Compound 4, largest response reached (reported as efficacy), in percent of the reference or control that the assay uses: 80%
Compound 4: the middle estimate sits 25 percentage points below what was measured, and the stated range covers the measured number.
By their numbers in this assay, from the lowest: compound 3; then compound 1; then compounds 2 and 4 (each within the scatter of the next).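

Going by these compounds alone, replacing 4-sulfamoylphenyl with furan-2-yl on the aromatic carbon next to the ring nitrogen gives no change at the digits printed from compound 2 to compound 4 (within the scatter) in this assay and is the first single-place reading at this position. In this pair, the maximal response of compound 2 does not require the sulfamoyl group or its hydrogen-bond donor, and a five-membered aromatic ring serves in place of the larger six-membered one.

On these data alone, whether an unsubstituted phenyl, a pyridine or a thiophene at this carbon gives the same response remains open. Nothing available explains why the two groups match.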